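The source may report more compounds than this note shows. Statements on the series, on what has been measured and on what is new or still open speak of the compounds shown alone.

Compound 1 `Nc1nc(-c2cccc(CO)c2)nc2sc(-c3ccco3)nc12` and compound 2 `Nc1nc(-c2ccc(CO)cc2)nc2sc(-c3ccco3)nc12` share a core; the difference between the two cores is not broken down here. In an assay on CHO cells for displacement of a labelled ligand from adenosine receptor A1 (Homo sapiens), read by scintillation counting, with a stated time of 3 h (on this read-out higher numbers stand for weaker inhibition and lower numbers for stronger inhibition), compound 1 gives 28 nM, while compound 2 gives 77.7 nM. Compound 3 `COc1ccc(-c2nc(N)c3nc(-c4ccco4)sc3n2)cc1` arises from compound 2 through (methoxy in place of hydroxymethyl on an aromatic carbon), and in this assay compound 3 gives 47.7 nM, so that the step was a 1.6-fold lower number from compound 2 to compound 3 (0.21 log units; within the scatter). Compound 4 `COc1cccc(-c2nc(N)c3nc(-c4ccco4)sc3n2)c1` arises from compound 1 through the same kind of change, (methoxy in place of hydroxymethyl on an aromatic carbon); the place differs, being meta to a large group in compound 4 but para to a large group in compound 3. Because the measured step was a 1.6-fold lower number from compound 2 to compound 3 (0.21 log units; within the scatter), a step of a 1.4-fold lower number from compound 1 to compound 4 (0.15 log units; within the scatter) is expected in this assay. The expected value for compound 4 is 20 nM, estimated to lie between 8 nM and 50 nM.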

Compound 4, inhibition constant: 62.3 nM
For compound 4 the middle estimate is 3.1-fold (0.49 log units) below the measured one; the measured number lies above the stated range.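

In this assay, putting methoxy in place of hydroxymethyl gives a 2.2-fold higher number from compound 1 to compound 4 (0.35 log units; beyond the scatter). Among the compounds shown here, this change therefore does not carry over as a fixed step from one core to the other, as the two steps set side by side show: the same change on two cores in this assay, a 1.6-fold lower number (0.21 log units; within the scatter) from compound 2 to compound 3 and a 2.2-fold higher number (0.35 log units; beyond the scatter) from compound 1 to compound 4, 3.6-fold (0.56 log units) apart, beyond the scatter of two such steps With only one pair of steps, this does not explain why they differ, and it gives no rule for other cores.

The compounds shown leave open whether a different group on the same aromatic carbon, such as an amine or a carboxylic acid, would shift the number in the same direction on both cores. They also leave open how a longer chain, such as ethoxy, would behave there.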